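From Hydroxymethyl to tert-Butoxycarbonyl on an Aromatic Nitrogen

The source may report more compounds than this note shows. Statements on the series, on what has been measured and on what is new or still open speak of the compounds shown alone.

In a functional assay on HeLa cells (Homo sapiens) for inhibition, read by CCK-8 assay, with a stated time of 48 h (on this read-out lower numbers stand for stronger inhibition and higher numbers for weaker inhibition), compound 1 (`COc1cc(-c2ccnc3cc(-c4cn(CO)c5ccccc45)nn23)cc(OC)c1OC`) gives 103 nM and compound 3 (`COc1cc(-c2ccnc3cc(-c4ccc5ccn(C)c5c4)nn23)cc(OC)c1OC`) gives 187 nM so these two values lie within the scatter of each other at the low end of the three numbers. Compound 2 (`Cn1ccc2cc(-c3cc4nccc(-c5ccc(F)cc5)n4n3)ccc21`) stands well apart at 5210 nM on the same read-out.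

Compound 4 (`COc1cc(-c2ccnc3cc(-c4cn(C(=O)OC(C)(C)C)c5ccccc45)nn23)cc(OC)c1OC`) keeps the core of compound 1 but has tert-butoxycarbonyl in place of hydroxymethyl on an aromatic nitrogen. Within the data shown here, no measured pair here differs in one place only, so no direct precedent exists for this change. Compound 3 carries no hydroxymethyl and still gives 187 nM so losing that group need not by itself bring a large rise. As far as these compounds go, the much larger entering group remains untested, and a moderate step toward weaker inhibition in this assay is expected, although a step within the scatter remains possible. The estimated step is a 2.9-fold higher number from compound 1 to compound 4 (0.46 log units; beyond the scatter) on this read-out. Compound 4 is expected at 300 nM with an estimated range of 90 nM to 1200 nM in this measurement.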

Compound 4, half-maximal inhibitory concentration: 3770 nM
Compound 4: the middle estimate sits 13-fold (1.10 log units) below what was measured; the whole stated range lies below it.
By their numbers in this assay, from the lowest: compounds 1 and 3 (each within the scatter of the next); then compounds 4 and 2 (each within the scatter of the next).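

On the aromatic nitrogen of the five-membered ring, the group carried matters in this assay. The core of compound 1 alone proves not to hold the low number. Tert-butoxycarbonyl in place of hydroxymethyl gives a 37-fold higher number from compound 1 to compound 4 (1.56 log units; beyond the scatter) and so marks a large move toward weaker inhibition. This is the first pair shown that differs in one place only, and it makes this nitrogen a position where a single change can cost much of the inhibition. Nothing measured here accounts for the step.

The compounds shown leave open whether the carbonyl or the tert-butyl part goes with the step, which an acetyl group on the same nitrogen would begin to separate. They also leave open how a methyl group, a plain hydrogen or a longer chain ending in an amine would read at this position.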